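Bromo for methyl in a stilbene-type phenol series

This account rests on a few compounds, and the source may have more. Where it says the series, first, only, none or still open, it means among the compounds named here.

Three compounds of the series have numbers in a functional assay on HT-29 cells (Homo sapiens) for antiproliferative activity, read by MTT assay; a higher number here means a weaker inhibitor, a lower number a stronger inhibitor. Compound 1 `COc1ccc(/C=C/c2cc(Br)ccc2O)c(OC)c1` gives 10000 nM. Compound 2 `Cc1ccc(/C=C/c2ccccc2O)cc1` gives 22900 nM. Compound 3 `COc1cc(/C=C/c2cc([N+](=O)[O-])ccc2O)cc(OC)c1` gives 12600 nM. Compound 2 has the highest of the three numbers: compound 3 sits close to it, with the gap between the two within the usual scatter, whereas compound 1 gives a clearly lower number, with that gap beyond the scatter. Within the data shown here, no pair of measured compounds differs in one place only, so no single-change step is available inside the measured set.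

Compound 4 `Oc1ccccc1/C=C/c1ccc(Br)cc1` has not been measured. It differs from compound 2 by bromo in place of methyl on an aromatic carbon. Among the measured compounds shown here, the only measured compound carrying a bromo, compound 1, gives 10000 nM, but it carries it on the other ring together with further groups, so it offers no direct reading of this exchange. The expected step from compound 2 to compound 4 is a 1.5-fold lower number from compound 2 to compound 4 (0.18 log units; within the scatter), a small move toward a lower number that does not go beyond the scatter. Compound 4 is therefore estimated at 15000 nM, with a range from 5000 nM to 45000 nM.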

Compound 4, half-maximal inhibitory concentration: 14400 nM
Estimate against measurement, compound 4: 1.0-fold (0.02 log units) above; low and high end bracket the measured number.
By their numbers in this assay, from the lowest: compounds 1, 3, 4 and 2 (each within the scatter of the next, the first and the last beyond it).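

In this assay, among these compounds, bromo in place of methyl on an aromatic carbon gives a 1.6-fold lower number from compound 2 to compound 4 (0.20 log units; within the scatter) and so provides the first single-change reading, at a site on a six-membered aromatic ring of carbon only, para to a group of 9 heavy atoms. At this site, the two groups cannot be told apart in this assay, something that compound 1 and compound 3 could not show, since each differs from compound 2 in more than one place. Nothing measured here speaks to the reason for this result.

As far as these compounds go, it remains open whether another group at the same site, such as an amine, a carboxylic acid or a longer chain, would move the number beyond the scatter of repeated measurements. From the compounds shown here alone, it also remains open whether bromo in place of methyl would read the same way on the core of compound 1 or the core of compound 3, which carry further groups.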